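The source may hold more compounds than are shown below. What is called first, only, known or untested is meant among the compounds shown, and "the series" means these compounds.

Compound 1 `COc1cccc(-c2c(C)n(Cc3c(F)cccc3F)c(=O)n(C[C@@H](N)CCc3ccccc3)c2=O)c1F`: 965 nM
Compound 2 `COc1cccc(-c2c(C)n(Cc3c(F)cccc3F)c(=O)n(C[C@H](N)C(C)C)c2=O)c1F`: 51 nM
Compound 3 `COc1cccc(-c2c(C)n(Cc3c(F)cccc3F)c(=O)n(C[C@@H](N)C3CCCC3)c2=O)c1F`: 94 nM

All three compounds share one core and differ only in the group attached to the saturated chain carbon bound to an aromatic nitrogen. In an assay on HEK293 cells for binding affinity to Gonadotropin-releasing hormone receptor (Homo sapiens), read by radioligand binding (on this read-out higher numbers stand for weaker inhibition and lower numbers for stronger inhibition), compound 3 gives 94 nM, the second highest of the three numbers. Its nearest neighbour is compound 2, with a 1.8-fold higher number from compound 2 to compound 3 (0.27 log units; within the scatter); the furthest is compound 1, with a 10-fold lower number from compound 1 to compound 3 (1.01 log units; beyond the scatter).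

Compound 4 `COc1cccc(-c2c(C)n(Cc3c(F)cccc3F)c(=O)n(C[C@H](N)C3CCCCC3)c2=O)c1F` has not yet been measured. It differs from compound 3 in one place: amino(cyclohexyl)methyl in place of amino(cyclopentyl)methyl on a saturated chain carbon bound to an aromatic nitrogen. The measured steps show that the group on this carbon matters a great deal when it changes in kind, as with a 19-fold lower number from compound 1 to compound 2 (1.28 log units; beyond the scatter) and a 10-fold lower number from compound 1 to compound 3 (1.01 log units; beyond the scatter). Between two small saturated groups, however, the change was modest: a 1.8-fold higher number from compound 2 to compound 3 (0.27 log units; within the scatter). Widening the ring by one carbon is closer to the second kind of change than to the first, so only a small step is expected in this assay, in either direction and likely within the scatter.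

For compound 4 the expected step from compound 3 is a 1.0-fold lower number from compound 3 to compound 4 (0.02 log units; within the scatter). Compound 4 is therefore estimated at 90 nM, with a range from 40 nM to 250 nM.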

Compound 4, inhibition constant: 6.5 nM
Estimate against measurement, compound 4: 14-fold (1.14 log units) above; measured number outside the range, below it.
By their numbers in this assay, from the lowest: compound 4; then compounds 2 and 3 (each within the scatter of the next); then compound 1.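

In this assay, among the compounds shown here, one extra ring carbon matters far more than the earlier compounds suggested, with a 14-fold lower number from compound 3 to compound 4 (1.16 log units; beyond the scatter), so saturated groups at this place are not interchangeable, even though the isopropyl of compound 2 and the cyclopentyl of compound 3 lie within the scatter of each other. The cyclohexyl group also stands clearly apart from the isopropyl group, with a 7.8-fold lower number from compound 2 to compound 4 (0.89 log units; beyond the scatter), and the spread at this position now reaches a 150-fold lower number from compound 1 to compound 4 (2.17 log units; beyond the scatter), which makes compound 4 the strongest binder of the four. Nothing available here explains why the six-membered ring gives so different a number from the five-membered one.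

The compounds shown leave open whether the number would keep falling with a still larger ring such as cycloheptyl, or whether the gain belongs to the six-membered ring alone. They also leave open what a phenyl group placed directly on this carbon, or a hydroxyl group on the cyclohexyl ring, would do to the number.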